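Shortening the acyl chain of a weak growth inhibitor

This account rests on a few compounds, and the source may have more. Where it says the series, first, only, none or still open, it means among the compounds named here.

The study describes three amides built on one shared core. Among the measured compounds shown here, compound 1, `CC(=O)N1c2ccccc2CCC1C(=O)Nc1ccccc1O`, is the first of them; in a functional assay on PC-3 cells (Homo sapiens) for cytotoxicity, read by sulforhodamine B assay, with a stated time of 72 h (on this read-out higher numbers stand for weaker inhibition of growth and lower numbers for stronger inhibition of growth), compound 1 gives 70700 nM. Compound 2, `CCCC(=O)N1c2ccccc2CCC1C(=O)Nc1ccccc1C(F)(F)F`, is the second. For compound 2 the assay returned only a limit, > 70000 nM, so its true value is not known as a number. This is the limit described by the limit of > 70000 nM in this assay, at which 1 of the 2 values shown sits. Compound 2 therefore stands at the edge of the assay's range among the numbers shown, and it can be placed no more precisely than that. Compound 3, `CCC(=O)N1c2ccccc2CCC1C(=O)Nc1ccccc1C(F)(F)F`, has not yet been measured in this assay. It differs from compound 2 by hydrogen in place of methyl on a saturated chain carbon, two bonds along the chain from a carbonyl carbon. No step between two measured compounds is shown, so the data give no measured guide to this kind of shortening. The writer expects the step that the limit leaves unreadable from compound 2 to compound 3 to be none beyond the usual scatter. Compound 3 is therefore estimated at 80000 nM, with a range from 30000 nM to 200000 nM, and it will most likely be reported only as a limit.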

Compound 3, concentration for 50% growth inhibition: > 80000 nM
Compound 3: no number, only a limit; the forecaster's own chance of this, stated with the estimate: 70%; the middle value lies on the limit itself.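

In this assay, among the compounds shown here, compound 2 and compound 3 are each reported only as a limit, not as a number, so no step between them can be read. The compounds shown leave open whether the change from propyl to ethyl has any effect on growth inhibition in this assay, and how large that effect might be.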